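Chain extension on the carbamate of compound 2

The source may report more compounds than this note shows. Statements on the series, on what has been measured and on what is new or still open speak of the compounds shown alone.

Compound 1 `CC(C)c1cccc(C(C)C)c1OC(=O)NC(=O)OCCCc1ccccc1` gives 660 nM in an assay on microsomes from intestine for inhibition of acyl-CoA:cholesterol acyltransferase (Oryctolagus cuniculus); a lower number here means a stronger inhibitor, a higher number a weaker inhibitor. Compound 2 `CCCCCCCC(C)OC(=O)NC(=O)Oc1c(C(C)C)cccc1C(C)C` gives 97 nM in this assay, the lowest of the two numbers; the step of a 6.8-fold lower number from compound 1 to compound 2 (0.83 log units; beyond the scatter) is the only measured one and lies beyond the scatter. Compound 3 `CCCCCCCCCCCCCCC(C)OC(=O)NC(=O)Oc1c(C(C)C)cccc1C(C)C` carries heptyl in place of hydrogen on a saturated chain carbon, eight bonds along the chain from an oxygen next to a carbonyl group, on a saturated chain carbon, eight bonds along the chain from an oxygen next to a carbonyl group. For the measured compounds named here, no measured step lengthens a saturated chain, so the one step that bears on it, a 6.8-fold lower number from compound 1 to compound 2 (0.83 log units; beyond the scatter), does so only loosely: it shows that the saturated chain in compound 2 gave a lower number than the ring-bearing group of compound 1, with no information on how much further chain is tolerated. The expected step of a 1.6-fold lower number from compound 2 to compound 3 (0.21 log units; within the scatter) in this assay is therefore small or within the scatter, with a lower number slightly favoured. Compound 3 is estimated at 60 nM, between 15 nM and 250 nM.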

Compound 3, half-maximal inhibitory concentration: 58 nM
Compound 3: the middle estimate sits 1.0-fold (0.01 log units) above what was measured, within the range that was stated.
By their numbers in this assay, from the lowest: compounds 3 and 2 (each within the scatter of the next); then compound 1.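

In this assay the step is a 1.7-fold lower number from compound 2 to compound 3 (0.22 log units; within the scatter) and so lies within the scatter: heptyl in place of hydrogen on a saturated chain carbon, eight bonds along the chain from an oxygen next to a carbonyl group, leaves compound 3 indistinguishable from compound 2. The earlier step of a 6.8-fold lower number from compound 1 to compound 2 (0.83 log units; beyond the scatter) compared a ring-bearing group with a saturated chain and said nothing about lengthening that chain; this position is now seen to accept the longer saturated chain of compound 3 with no loss beyond the scatter. No measured evidence is available to account for this result.

On these data alone, whether a chain longer than that of compound 3 would still be accepted at this position remains open. Also open, as far as these compounds go, is how a carboxylic acid, an amine or a phenyl ring at the far end of the chain would behave.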